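Adding a Second Methoxy Group to Compound 1

A few compounds are considered here, and "the series" means these few. Any claim that something is new, unique, unknown or untested is made for them only; others in the source may bear on it.

Measured in a functional assay on MDA-MB-468 cells (Homo sapiens) for inhibition, read by sulforhodamine B assay, with a stated time of 48 h; on this read-out higher numbers stand for lower toxicity in this test and lower numbers for higher toxicity in this test:
compound 1 `COc1ccc(-c2cc(/C=C/C(=O)c3ccc(N)cc3)[nH]n2)cc1`: 7450 nM
compound 2 `COc1ccc(C(=O)/C=C/c2cc(-c3cc(OC)c(OC)c(OC)c3)n[nH]2)cc1OC`: 5210 nM
compound 3 `COc1ccc(C(=O)/C=C/c2cc(-c3cc(OC)c(OC)c(OC)c3)n[nH]2)cc1`: 5450 nM

The value of compound 1 lies within the scatter of both compound 2 and compound 3, so this assay does not separate the three. The change to compound 4 `COc1ccc(-c2cc(/C=C/C(=O)c3ccc(N)cc3)[nH]n2)cc1OC` is methoxy in place of hydrogen on an aromatic carbon. Going by the values given here, one measured step bears on it, running in the opposite direction: a 1.0-fold higher number from compound 2 to compound 3 (0.02 log units; within the scatter), where taking a methoxy group away left the number inside the scatter. On that basis no step beyond the scatter is expected in this assay, the expected change being a 1.1-fold lower number from compound 1 to compound 4 (0.03 log units; within the scatter). Compound 4 is therefore estimated at 7000 nM, with a range from 3500 nM to 14000 nM.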

Compound 4, concentration lethal to 50% of the cells: 7800 nM
The estimate for compound 4 lay 1.1-fold (0.05 log units) below the measured number, and the stated range covers the measured number.
By their numbers in this assay, from the lowest: compounds 2, 3, 1 and 4 (each within the scatter of the next).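

Methoxy in place of hydrogen, ortho to a methoxy group, now has a direct reading on the core of compound 1: in this assay the step is a 1.0-fold higher number from compound 1 to compound 4 (0.02 log units; within the scatter). The earlier compounds showed this change only on a different core, and the two readings now agree in this assay: the same change on two cores in this assay, a 1.0-fold higher number (0.02 log units; within the scatter) from compound 2 to compound 3 and a 1.0-fold lower number (0.02 log units; within the scatter) from compound 4 to compound 1, 1.1-fold (0.04 log units) apart, within the scatter of two such steps

Still open, going by these compounds, is whether a hydroxyl group, a fluorine atom or a longer alkoxy chain on this aromatic carbon would give a step beyond the scatter.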